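Hydroxy on the Amide Nitrogen of Compound 3

This account rests on a few compounds, and the source may have more. Where it says the series, first, only, none or still open, it means among the compounds named here.

Measured in a toxicity assay on HepG2 cells (Homo sapiens) for inhibition, read by resazurin assay, with a stated time of 24 h; on this read-out higher numbers stand for lower toxicity in this test and lower numbers for higher toxicity in this test:
Compound 1 `O=C(NC1CCCCC1)c1ncc([N+](=O)[O-])[nH]1`: > 100000 nM
Compound 2 `NC(=O)c1nc([N+](=O)[O-])cn1Cc1ccc(F)cc1`: > 100000 nM
Compound 3 `NC(=O)c1nc([N+](=O)[O-])cn1Cc1ccc(OC(F)(F)F)cc1`: > 100000 nM

Compound 3 stands at > 100000 nM and this is a limit, not a number. The same holds across the set, with the limit of > 100000 nM in this assay, at which 3 of the 3 values shown sit, as the common reading. Compound 4 `O=C(NO)c1nc([N+](=O)[O-])cn1Cc1ccc(OC(F)(F)F)cc1` carries hydroxy in place of hydrogen on an amide-type nitrogen, counted as hydroxy in place of hydrogen on an amide-type nitrogen and turning carbamoyl to hydroxycarbamoyl. Going by the values given here, the only measured step, a step that the two limits leave unreadable from compound 2 to compound 3 and with trifluoromethoxy in place of fluoro, sits at another place and gives no size for this change. Only a modest shift toward lower numbers is therefore expected, estimated as an at least 1.4-fold lower number from compound 3 to compound 4 (0.15 log units; that floor lies within the scatter) in this direction. For compound 4 the estimate is 70000 nM with an expected range of 20000 nM to 100000 nM and a fair chance of another limit.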

Compound 4, half-maximal cytotoxic concentration: > 100000 nM
Compound 4 gave a limit, no number; the forecaster's own chance of this, stated with the estimate: 60%; middle value at least 1.4-fold (0.15 log units) away from the limit.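

In this assay compound 4 gives > 100000 nM, which is a limit and not a number, so no step can be read from compound 3 to compound 4. The compounds shown leave open how far hydroxy in place of hydrogen on an amide-type nitrogen shifts this read-out, since all of them share one reading: the limit of > 100000 nM in this assay, at which 4 of the 4 values shown sit.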